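Removing the acetyl group from compound 2

The source may hold more compounds than are shown below. What is called first, only, known or untested is meant among the compounds shown, and "the series" means these compounds.

In a functional assay on SK-BR-3 cells (Homo sapiens) for antiproliferative activity (a higher number here means a weaker inhibitor, a lower number a stronger inhibitor), compound 2 (`CC(=O)Oc1ccc(C(=O)Nc2cc3ccc(OCC4CCCNC4)c(C)c3oc2=O)cc1CC=C(C)C`) gives 620 nM. Compound 1 (`CC(=O)Oc1ccc(C(=O)Nc2cc3ccc(OCC4CCN(C)C4)c(C)c3oc2=O)cc1CC=C(C)C`) gives 880 nM and compound 3 (`CC(C)=CCc1cc(C(=O)Nc2cc3ccc(OCCC4CCCCN4)c(C)c3oc2=O)ccc1O`) gives 640 nM, so all three values lie within the scatter of one another.

Compound 4 (`CC(C)=CCc1cc(C(=O)Nc2cc3ccc(OCC4CCCNC4)c(C)c3oc2=O)ccc1O`) differs from compound 2 by one change, acetoxy to hydroxy, with hydrogen in place of acetyl on an oxygen on an aromatic ring. Going by the values given here, no measured pair isolates this change. Among the compounds with values here, the one measured step, a 1.4-fold lower number from compound 1 to compound 2 (0.15 log units; within the scatter), swaps 1-methylpyrrolidin-3-yl for piperidin-3-yl at a different place and stays within the scatter, so it bears only indirectly. Within the data shown here, compound 3 is the one measured compound with a hydroxy group at this place, and its 640 nM gives no sign of a large shift.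

No step beyond the scatter is therefore expected, and the estimated step is a 1.0-fold lower number from compound 2 to compound 4 (0.01 log units; within the scatter). Compound 4 is expected at 600 nM, with an estimated range from 250 nM to 1400 nM.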

Compound 4, half-maximal inhibitory concentration: 600 nM
Estimate against measurement, compound 4: no gap at the digits printed; measured number inside the range.
By their numbers in this assay, from the lowest: compounds 4, 2, 3 and 1 (each within the scatter of the next).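

Acetoxy and hydroxy on this aromatic ring now form a direct pair, which the earlier compounds did not offer, and in this assay the step is a 1.0-fold lower number from compound 2 to compound 4 (0.01 log units; within the scatter), so the two groups cannot be told apart in this setting. With the hydroxy group held fixed, piperidin-3-yl in place of (piperidin-2-yl)methyl on the chain bound to the oxygen on the aromatic ring gives a 1.1-fold lower number from compound 3 to compound 4 (0.03 log units; within the scatter), so this swap cannot be told apart either. Nothing measured here accounts for these results.

Still open, going by these compounds, is whether a methoxy group or a longer acyl group such as benzoyl on this oxygen would stay in the same range. On these data alone, it is also open whether hydrogen in place of acetyl would give the same result with the 1-methylpyrrolidin-3-yl group of compound 1.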